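The source may report more compounds than this note shows. Statements on the series, on what has been measured and on what is new or still open speak of the compounds shown alone.

So far, two compounds have been measured in a functional assay on XF498 cells (Homo sapiens) for cytotoxicity; on this read-out higher numbers stand for an effect only at larger amounts of compound and lower numbers for an effect already at smaller amounts. Compound 1 (`C#C/C=C\CCCCCCCCCCCCCCC/C=C\CCCC/C=C\CCCCC#C[C@@H](O)C#CCCCCCC/C=C/[C@H](O)C#C`) gives 2.5 ug/mL and compound 2 (`C#C/C=C\CCCCCCCCCCCCC/C=C\CCCC/C=C\CCCCC#C[C@@H](O)C#CCCCCCC/C=C/[C@H](O)C#C`) gives 6.1 ug/mL as the higher of the two numbers. Compound 3 (`C#C/C=C\CCCCCCCCCCCCCC/C=C\CCCC/C=C\CCCCC#C[C@@H](O)C#CCCCCCC/C=C/[C@H](O)C#C`) is still unmeasured. It differs from compound 2 as follows (a group of 5 heavy atoms (5 carbon; no ring) in place of a group of 4 heavy atoms (4 carbon; no ring), on a saturated chain carbon, ten or more bonds along the chain from a double-bonded chain carbon). For the measured compounds named here, the one measured step that bears on this, a 2.4-fold higher number from compound 1 to compound 2 (0.39 log units; beyond the scatter) on going from a group of 6 heavy atoms to a group of 4 heavy atoms, is modest. Compound 3 holds a group of 5 heavy atoms, so in this assay a partial move back toward compound 1 (2.5 ug/mL) is expected, which means a lower number and a smaller step, perhaps within the scatter. A single step makes this a rough guide. The expected change is modest (a 1.6-fold lower number from compound 2 to compound 3 (0.19 log units; within the scatter)). For compound 3 the estimated value is 3.9 ug/mL with an expected range of 2 ug/mL to 7.5 ug/mL on repeat measurement.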

Compound 3, concentration for half-maximal effect: 5.8 ug/mL
Beside the measured number, compound 3's estimate is 1.5-fold (0.17 log units) below it; the measured number falls inside the stated range.
By their numbers in this assay, from the lowest: compound 1; then compounds 3 and 2 (each within the scatter of the next).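

In this assay the change at this saturated chain carbon gives a 1.1-fold lower number from compound 2 to compound 3 (0.02 log units; within the scatter) and so the group of 5 heavy atoms and the group of 4 heavy atoms cannot be told apart here. The same read-out gives a 2.3-fold higher number from compound 1 to compound 3 (0.37 log units; beyond the scatter) and so, among these three compounds, the gap lies only between the group of 6 heavy atoms and the two smaller groups, not in even steps along the series. No measurement at hand explains this pattern.

From the compounds shown here alone, whether a still longer chain at this place would lower the number further remains open. So does whether a chain ending in a hydroxyl group or an amine would behave like these all-carbon groups, and whether the pattern holds on other cell lines.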